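Dropping the Dimethylcarbamoyl Cap from a Pyrazole Amide

A few compounds are considered here, and "the series" means these few. Any claim that something is new, unique, unknown or untested is made for them only; others in the source may bear on it.

Compound 1 `CN(C)C(=O)n1ccc(-c2ccc(Oc3ccc(F)cc3)cc2)n1` is the weakest of the three measured compounds in an assay on HEK293 cells for binding affinity to sodium channel protein type 4 subunit alpha (Homo sapiens) (on this read-out lower numbers stand for stronger inhibition and higher numbers for weaker inhibition), where compound 1 gives 340 nM. Its two companions share the same core: compound 3 `NC(=O)n1ccc(-c2ccc(Oc3ccc(F)cc3)cc2)n1` gives 31 nM, and compound 2 `NC(=O)n1ccc(-c2ccc(Oc3ccc(F)cc3F)cc2)n1` gives 25 nM. The step of an 11-fold lower number from compound 1 to compound 3 (1.04 log units; beyond the scatter) was large, whereas a 1.2-fold higher number from compound 2 to compound 3 (0.09 log units; within the scatter) was not. Compound 4 `Fc1ccc(Oc2ccc(-c3cc[nH]n3)cc2)cc1` differs from compound 1 by hydrogen in place of dimethylcarbamoyl on an aromatic nitrogen. Going by the values given here, only the step from compound 1 to compound 3 bears on this change, and only in part: there the dimethylamino was pared back to amino while the carbonyl stayed, and the number fell steeply. Among the compounds with values here, no measured pair removes the whole dimethylcarbamoyl. The account therefore expects that compound 4 moves in the same direction as compound 3 but by a smaller and less certain amount. For compound 4 the expected step is a 2.8-fold lower number from compound 1 to compound 4 (0.45 log units; beyond the scatter). Compound 4 is thus estimated at 120 nM, with a range from 25 nM to 600 nM.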

Compound 4, inhibition constant: 200 nM
The estimate for compound 4 lay 1.7-fold (0.22 log units) below the measured number; the measured number falls inside the stated range.
By their numbers in this assay, from the lowest: compounds 2 and 3 (each within the scatter of the next); then compounds 4 and 1 (each within the scatter of the next).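

In this assay, removing the whole dimethylcarbamoyl gives a 1.7-fold lower number from compound 1 to compound 4 (0.23 log units; within the scatter), so hydrogen and dimethylcarbamoyl on this aromatic nitrogen cannot be told apart. The same hydrogen compares poorly with the carbamoyl, with a 6.5-fold higher number from compound 3 to compound 4 (0.81 log units; beyond the scatter), which shows that the low number of compound 3 depends on the complete carbamoyl and does not come simply from shedding the dimethylcarbamoyl. No measurement at hand explains why the carbamoyl stands apart from both hydrogen and dimethylcarbamoyl.

The compounds shown leave open where a methylamino on the same carbonyl would fall, and whether an acetyl group on the aromatic nitrogen would keep the number of compound 3. They also leave open whether a second fluoro, as carried by compound 2, would matter on the core of compound 4.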